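Methoxy to Methylsulfanyl on a Fused Core

The source may report more compounds than this note shows. Statements on the series, on what has been measured and on what is new or still open speak of the compounds shown alone.

Measured so far:
- compound 1, `CCc1c(SC)nc2nc(-c3noc(C)n3)cn2c1C`: 2 mg/kg
- compound 2, `CCc1c(OC)nc2nc(-c3nnc(C)o3)cn2c1C`: 2 mg/kg

In a functional assay on the whole organism with Rattus norvegicus as the target (on this read-out higher numbers stand for an effect only at larger amounts of compound and lower numbers for an effect already at smaller amounts), compound 2 gives 2 mg/kg, level with compound 1 at the digits shown. Compound 3, `CCc1c(SC)nc2nc(-c3nnc(C)o3)cn2c1C`, is not yet measured. It differs from compound 2 by methylsulfanyl in place of methoxy on an aromatic carbon. Going by the values given here, no measured pair shows this exchange on its own, so its size is unknown here. Compound 1 also carries methylsulfanyl and gives 2 mg/kg, so no step beyond the scatter is expected in this assay. For compound 3 the estimate is 2 mg/kg, with a range from 1 mg/kg to 4 mg/kg, meaning an expected step of no change at the digits printed from compound 2 to compound 3 (within the scatter).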

Compound 3, minimum effective dose: 5 mg/kg
The estimate for compound 3 lay 2.5-fold (0.40 log units) below the measured number; measured number outside the range, above it.
By their numbers in this assay, from the lowest: compounds 1 and 2 (each within the scatter of the next); then compound 3.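

In this assay, swapping methoxy for methylsulfanyl on this aromatic carbon gives a 2.5-fold higher number from compound 2 to compound 3 (0.40 log units; beyond the scatter), so a larger amount of compound is needed for an effect. The ring at the other site also counts: 5-methyl-1,3,4-oxadiazol-2-yl in place of 5-methyl-1,2,4-oxadiazol-3-yl gives a 2.5-fold higher number from compound 1 to compound 3 (0.40 log units; beyond the scatter). Compound 1 and compound 2 differ in both places, so their matching values could not show either step.

Nothing available explains either step. Still open, as far as these compounds go, is how ethoxy or an amine would fare on this carbon, and whether methoxy would change the result alongside 5-methyl-1,2,4-oxadiazol-3-yl.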